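Methyl on the Aromatic Ring of a Quinoline-Free Described Core

The source may report more compounds than this note shows. Statements on the series, on what has been measured and on what is new or still open speak of the compounds shown alone.

Measured compounds:
- compound 1 `CCc1cccc2cc(C(=O)O)cnc12`: 75 mg/kg
- compound 2 `Cc1cccc2cc(C(=O)O)cnc12`: > 25 mg/kg

Compound 1 carries an ethyl group and in a functional assay on the whole organism (strain Sprague-Dawley) for inhibition, with Rattus norvegicus as the target (on this read-out higher numbers stand for an effect only at larger amounts of compound and lower numbers for an effect already at smaller amounts), compound 1 gives 75 mg/kg. Compound 2 has a shorter chain, and in this assay compound 2 gives > 25 mg/kg, which is a limit of the assay rather than a number. Compound 2 therefore stands at a limit, described by the limit of > 25 mg/kg in this assay, at which 1 of the 2 values shown sits. The step that the limit leaves unreadable from compound 1 to compound 2 is hydrogen in place of methyl on a saturated chain carbon bound to an aromatic carbon, and its size cannot be read.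

Compound 3 `Cc1ccc2cc(C(=O)O)cnc2c1C` differs from compound 2 by methyl in place of hydrogen on an aromatic carbon. Going by the values given here, no measured step bears on this kind of change, so no direction beyond the scatter is expected, and compound 2 itself supplies only a limit. Compound 3 is estimated at 40 mg/kg in this assay, with a range from 15 mg/kg to 150 mg/kg. The step that the limit leaves unreadable from compound 2 to compound 3 is expected to be small.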

Compound 3, minimum effective dose: 50 mg/kg
Estimate against measurement, compound 3: 1.3-fold (0.10 log units) below; low and high end bracket the measured number.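

No size can be read for the change from compound 2 to compound 3, because compound 2 stands only at a limit of the assay: the limit of > 25 mg/kg in this assay, at which 1 of the 3 values shown sits.
The compounds shown leave open how much methyl in place of hydrogen on the aromatic carbon shifts the minimum effective dose.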